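A small side-chain change from compound 3 to compound 4

The compounds below may be only part of what the source reports. "The series", "measured", "known", "first", "only" and "open" are said of these compounds alone.

Measured values in a functional assay on HeLa cells (Homo sapiens) for antiproliferative activity, read by MTT assay, with a stated time of 72 h (a lower number here means a stronger inhibitor, a higher number a weaker inhibitor), so far:
Compound 1 `CC(C)/C=C/C(=O)Nc1cccc(Oc2nc(Nc3cccc(C#N)c3)nc3c2CSCC3)c1` gives 22800 nM
Compound 2 `CC/C=C/C(=O)Nc1cccc(Oc2nc(Nc3ccc(OC)cc3)nc3c2CSCC3)c1` gives 27200 nM
Compound 3 `COc1ccc(Nc2nc3c(c(Oc4cccc(NC(=O)C=C(C)C)c4)n2)CSCC3)cc1` gives 19100 nM

Compound 3 stands within the usual scatter of both other compounds. Compound 4 `COc1ccc(Nc2nc3c(c(Oc4cccc(NC(=O)/C=C/C(C)C)c4)n2)CSCC3)cc1` keeps the rest of compound 3 but has 3-methylbut-1-en-1-yl in place of 2-methylprop-1-en-1-yl on a carbonyl carbon. Among the compounds with values here, the one measured step at this place (a 1.4-fold lower number from compound 2 to compound 3 (0.15 log units; within the scatter)) is small. Compound 1 carries the same entering group and gives 22800 nM with another difference elsewhere. The estimated change (a 1.0-fold higher number from compound 3 to compound 4 (0.02 log units; within the scatter)) is therefore small, and no step beyond the scatter is expected in this assay here. Compound 4 is estimated at 20000 nM with an expected range from 11000 nM to 35000 nM for repeat measurements.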

Compound 4, half-maximal inhibitory concentration: 22900 nM
Compound 4: the middle estimate sits 1.1-fold (0.06 log units) below what was measured; low and high end bracket the measured number.
By their numbers in this assay, from the lowest: compounds 3, 1, 4 and 2 (each within the scatter of the next).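

In this assay the change on this carbonyl carbon (a 1.2-fold higher number from compound 3 to compound 4 (0.08 log units; within the scatter)) lies within the scatter, so 3-methylbut-1-en-1-yl and 2-methylprop-1-en-1-yl cannot be told apart here. A methyl in place of hydrogen on the saturated chain carbon (a 1.2-fold lower number from compound 2 to compound 4 (0.07 log units; within the scatter)) also lies within the scatter. With this side chain held constant, 4-methoxyphenyl in place of 3-cyanophenyl on the nitrogen (a 1.0-fold higher number from compound 1 to compound 4 (0.00 log units; within the scatter)) does too.

No supporting data are available to explain these numbers. Going by these compounds, whether an amine or a carboxylic acid on this chain would shift the number beyond the scatter remains open.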